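Moving a Fluorine Around the Outer Ring

This account rests on a few compounds, and the source may have more. Where it says the series, first, only, none or still open, it means among the compounds named here.

Compound 1, `CC[C@@H](Nc1c(C#N)c(-c2ccc(-c3ccc(F)cc3)cc2)nc2cnccc12)C(N)=O`: 2.7
Compound 2, `CC[C@@H](Nc1c(C#N)c(-c2ccc(-c3cccc(C)c3F)cc2)nc2cnccc12)C(=O)O`: 2.1

Of the compounds shown here, two have been measured in a physicochemical assay for lipophilicity, read by HPLC, at pH 7.5; on this read-out higher numbers stand for higher lipophilicity and lower numbers for lower lipophilicity. Compound 1 gives 2.7, the higher of the two numbers. Compound 2 carries a carboxylic acid where compound 1 carries a primary amide and has a differently substituted outer ring. In this assay compound 2 gives 2.1; the gap between the two lies beyond the scatter, so compound 1 stands clearly above compound 2 on this read-out.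

Compound 3, `CC[C@@H](Nc1c(C#N)c(-c2ccc(-c3ccccc3F)cc2)nc2cnccc12)C(N)=O`, has not yet been measured in this assay. It keeps the amide and the whole core of compound 1 and differs only in the outer ring: 2-fluorophenyl in place of 4-fluorophenyl on an aromatic carbon. The same atoms are present, joined differently, so no change in size or in the count of donors and acceptors accompanies the step.

Within the data shown here, no step between two measured compounds of this kind is available. The expectation rests on compound 1 alone. The step from compound 1 to compound 3 is expected to be small, likely a slight drop that stays within the scatter: a number 0.10 log units lower from compound 1 to compound 3 (within the scatter). Compound 3 is therefore estimated at 2.6, with a plausible range from 2.3 to 2.9.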

Compound 3, distribution coefficient: 2.7
Compound 3: the middle estimate sits 0.10 log units below what was measured, and the stated range covers the measured number.
By their numbers in this assay, from the lowest: compound 2; then compounds 1 and 3 (each within the scatter of the next).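

In this assay, taking the fluorine from its place in 4-fluorophenyl to its place in 2-fluorophenyl gives no change at the digits printed from compound 1 to compound 3 (within the scatter), so this read-out does not tell these two placements apart. The earlier pair could not show this, as compound 1 and compound 2 differ in more than one place, whereas compound 1 and compound 3 form a clean pair in which the outer ring alone is altered, with the same atoms and the rest of the molecule untouched. This is a single pair and a single kind of change, and nothing measured here accounts for the absence of a visible step between the two placements.

Compound 2 pairs a carboxylic acid with a differently substituted outer ring, and the share of each in its number cannot be read from these compounds. Going by these compounds, whether a chlorine, a methoxy group or a plain phenyl ring in place of the fluorinated ring would read the same as compound 1 and compound 3 also remains open.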